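A larger side chain on compound 3

The compounds below may be only part of what the source reports. "The series", "measured", "known", "first", "only" and "open" are said of these compounds alone.

Measured so far in a functional assay on the whole organism with Mus musculus as the target; a lower number here means that less compound is needed, a higher number that more compound is needed for the effect
Compound 1 `NC(=O)CNCc1ccccc1` gives 490 mg/kg
Compound 2 `CN(CC(N)=O)Cc1ccc(OCc2cccc(Cl)c2)cc1` gives 114 mg/kg
Compound 3 `CNC(=O)[C@@H](C)NCc1ccc(OCc2ccccc2)cc1` gives 40.5 mg/kg

Compound 3 stands lowest of the three in this assay at 40.5 mg/kg and lies beyond the scatter from both other compounds. Compound 4 `CNC(=O)[C@@H](NCc1ccc(OCc2ccccc2)cc1)C(C)C` carries 2-methyl-1-(methylcarbamoyl)propyl in place of 1-(methylcarbamoyl)ethyl on an amine nitrogen and is otherwise the same as compound 3. Among the measured compounds shown here, no measured pair shows this change on its own, so the expectation is loose. In this assay a modest rise is expected, and the estimated step of a 1.5-fold higher number from compound 3 to compound 4 (0.17 log units; within the scatter) may stay within the scatter. For compound 4 the estimated value is 60 mg/kg with an expected range from 25 mg/kg to 150 mg/kg in this measurement.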

Compound 4, dose for half-maximal effect: 55.4 mg/kg
Compound 4: the middle estimate sits 1.1-fold (0.03 log units) above what was measured, within the range that was stated.
By their numbers in this assay, from the lowest: compounds 3 and 4 (each within the scatter of the next); then compound 2; then compound 1.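

Within this assay, placing 2-methyl-1-(methylcarbamoyl)propyl in place of 1-(methylcarbamoyl)ethyl on an amine nitrogen gives a 1.4-fold higher number from compound 3 to compound 4 (0.14 log units; within the scatter) as the first step between measured compounds that differ in one place. It shows that this position takes the larger side chain with no separation beyond the scatter, at least for this pair. The compounds shown leave open whether a longer chain, a benzyl group or a carboxylic acid at this position would also stay within the scatter of compound 3. Nothing at hand accounts for the size of this step.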